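A few compounds are considered here, and "the series" means these few. Any claim that something is new, unique, unknown or untested is made for them only; others in the source may bear on it.

Measured in a physicochemical assay for lipophilicity; on this read-out lower numbers stand for lower lipophilicity and higher numbers for higher lipophilicity:
- Compound 1 `CCn1cnc2c(-c3ccc(F)c(-c4ccc(S(=O)(=O)CC)cc4)c3)cnnc21`: 2.9
- Compound 2 `CCn1cnc2c(-c3ccc(F)c(-c4ccc(S(=O)(=O)CC)cc4Cl)c3)cnnc21`: 3.2

In this assay, among the compounds with values here, compound 1 gives 2.9, and the only other measured compound lies within the usual scatter of it. Compound 3 `CCn1cnc2c(-c3ccc(F)c(-c4ccc(C(=O)N(C)C)cc4)c3)cnnc21` has not yet been measured. It keeps the core of compound 1 and differs at a single place, with dimethylcarbamoyl in place of ethylsulfonyl on an aromatic carbon.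

Within the data shown here, the one measured step is a number 0.30 log units higher from compound 1 to compound 2 (within the scatter), and it comes from chloro in place of hydrogen on an aromatic carbon. This step bears only loosely on the new change, since compound 2 retains the ethylsulfonyl group. Among the measured compounds shown here, no measured pair replaces that group, so the data offer no direct guide to the size or direction of the change. The leaving and entering groups have the same number of heavy atoms and neither carries a net charge. The expectation is therefore no step beyond the scatter, starting from compound 1 at 2.9. The expected step is a number 0.10 log units lower from compound 1 to compound 3 (within the scatter). The estimate for compound 3 is 2.8, with an expected range of 2.3 to 3.3.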

Compound 3, distribution coefficient: 2.5
Compound 3: middle estimate off by 0.30 log units, on the high side; low and high end bracket the measured number.
By their numbers in this assay, from the lowest: compound 3; then compounds 1 and 2 (each within the scatter of the next).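

In this assay, within the data shown here, dimethylcarbamoyl in place of ethylsulfonyl on an aromatic carbon, para to a large group, gives a number 0.40 log units lower from compound 1 to compound 3 (beyond the scatter) and provides the first measured change at this position. The read-out at this position therefore responds to the exchange of one group for another, even though the two groups have the same number of heavy atoms and neither carries a net charge. Among these compounds, this differs from the only earlier step, the chloro change, which gives a number 0.30 log units higher from compound 1 to compound 2 (within the scatter) and stays within the usual scatter. No measurement at hand accounts for the step from ethylsulfonyl to dimethylcarbamoyl.

The compounds shown leave open how a carboxylic acid, an amine or a longer sulfonyl chain would read at this position, and whether a smaller amide would follow dimethylcarbamoyl or stay closer to ethylsulfonyl. They also leave open whether the dimethylcarbamoyl change would give a similar step with the chloro of compound 2 in place, since a single pair cannot show how the two changes combine.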